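A few compounds are considered here, and "the series" means these few. Any claim that something is new, unique, unknown or untested is made for them only; others in the source may bear on it.

Series notes on the measured compounds:

Compound 1 `O=c1sc2cc(NS(=O)(=O)c3ccccc3)ccc2n1CCN1CCCC1`: 11%
Compound 2 `O=c1sc2cc(NS(=O)(=O)c3ccccc3)ccc2n1CCN1CCCCC1`: 6%
Compound 3 `CN(c1ccccc1)S(=O)(=O)c1ccc2c(c1)sc(=O)n2CCN1CCCC1`: 10%

All three numbers come from an assay on HEK293 cells for displacement of a labelled ligand from 5-hydroxytryptamine receptor 6 (Homo sapiens), read by radioligand binding, with a stated time of 60 min, tested at 100 nM; on this read-out higher numbers stand for more inhibition at the one concentration tested (going by the name of the read-out) and lower numbers for less inhibition. Compound 1 and compound 2 share one core and differ in a single place, (piperidin-1-yl in place of pyrrolidin-1-yl on a saturated chain carbon, two bonds along the chain from an aromatic nitrogen); this change gave a number 5 percentage points lower from compound 1 to compound 2 (within the scatter). Compound 3 stands on a different core, and how that core differs from the core of compound 1 is not broken down here. The number for compound 3 lies within the scatter of compound 1 and also within the scatter of compound 2, so no order among the three can be stated.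

Compound 4 `CN(c1ccccc1)S(=O)(=O)c1ccc2c(c1)sc(=O)n2CCN1CCCCC1` has not yet been measured. Within the data shown here, it differs from compound 3 by piperidin-1-yl in place of pyrrolidin-1-yl on a saturated chain carbon, two bonds along the chain from an aromatic nitrogen, which is the same change as the one between compound 1 and compound 2. Because the earlier instance gave a number 5 percentage points lower from compound 1 to compound 2 (within the scatter), the step in this assay is expected to be a number 4 percentage points lower from compound 3 to compound 4 (within the scatter), again within the scatter. Compound 4 is accordingly estimated at 6%, with a range from -5% to 16%.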

Compound 4, a percentage reported as inhibition, at one concentration (the size of the read-out at that concentration, not a potency): 0%
Beside the measured number, compound 4's estimate is 6 percentage points above it; the range from low to high includes it.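

In this assay, piperidin-1-yl in place of pyrrolidin-1-yl on the core of compound 3 gave a number 10 percentage points lower from compound 3 to compound 4 (within the scatter). Set beside the earlier instance, the step does not differ between the two cores: the same change on two cores in this assay, a number 5 percentage points lower (within the scatter) from compound 1 to compound 2 and a number 10 percentage points lower (within the scatter) from compound 3 to compound 4, 5 percentage points apart, within the scatter of two such steps. This shows that the change can be carried across these two cores without a discernible difference in its step, but it does not show a real effect of the change on either core, and two cores support no rule for others.

The compounds shown leave open whether a different amine in the same place, such as morpholin-4-yl or dimethylamino, would give a step beyond the scatter. Going by these compounds, a longer chain between the aromatic nitrogen and the amine also remains open.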